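The source may report more compounds than this note shows. Statements on the series, on what has been measured and on what is new or still open speak of the compounds shown alone.

Measured so far in a functional assay on MGC-803 cells (Homo sapiens) for inhibition, read by sulforhodamine B assay; a higher number here means a weaker inhibitor, a lower number a stronger inhibitor:
- Compound 1 `O=C1C=C(NC2CCCCC2)C(=O)c2c1nc1n2[C@H]2OC[C@@H](O)[C@H]2OC1` gives > 8000 nM, which is a limit of the assay and not a number.
- Compound 2 `CCc1ccc(NC2=CC(=O)c3nc4n(c3C2=O)[C@H]2OC[C@@H](O)[C@H]2OC4)cc1` gives 1290 nM.
- Compound 3 `CCOc1ccccc1NC1=CC(=O)c2nc3n(c2C1=O)[C@H]1OC[C@@H](O)[C@H]1OC3` gives 2450 nM.

Among the compounds with values here, compound 3 stands level with the only other exact reading, as the step of a 1.9-fold higher number from compound 2 to compound 3 (0.28 log units; within the scatter) shows. Compound 4 `O=C1C=C(Nc2ccccc2)C(=O)c2c1nc1n2[C@H]2OC[C@@H](O)[C@H]2OC1` has hydrogen in place of ethoxy on an aromatic carbon, so that 2-ethoxyphenyl becomes phenyl (hydrogen in place of ethoxy on an aromatic carbon). Within the data shown here, no measured pair shows this exact change. The nearest evidence is the swap of 4-ethylphenyl for 2-ethoxyphenyl, which stayed within the scatter. The larger steps, an at least 6.2-fold lower number from compound 1 to compound 2 (0.79 log units; beyond the scatter) and an at least 3.2-fold lower number from compound 1 to compound 3 (0.51 log units; beyond the scatter), both replace cyclohexyl with a substituted phenyl, and compound 4 keeps a phenyl on that nitrogen. A change in this assay beyond the scatter is therefore not expected. The expected step is a 1.2-fold lower number from compound 3 to compound 4 (0.09 log units; within the scatter), with no firm direction. For compound 4 the estimated value is 2000 nM, with an expected range from 800 nM to 6000 nM.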

Compound 4, half-maximal inhibitory concentration: 1730 nM
The estimate for compound 4 lay 1.2-fold (0.06 log units) above the measured number; low and high end bracket the measured number.
By their numbers in this assay, from the lowest: compounds 2, 4 and 3 (each within the scatter of the next). At a limit, above all of these: compound 1.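

In this assay, the plain phenyl on this nitrogen performs like the substituted rings: taking away the ethoxy gives a 1.4-fold lower number from compound 3 to compound 4 (0.15 log units; within the scatter) and taking away the ethyl gives a 1.3-fold higher number from compound 2 to compound 4 (0.13 log units; within the scatter) so neither group is needed to reach this level of inhibition. Phenyl in place of cyclohexyl gives an at least 4.6-fold lower number from compound 1 to compound 4 (0.66 log units; beyond the scatter) and this shows that the aromatic ring alone, without any substituent, is enough for a step beyond the scatter. The reading for compound 1 is a limit and not a number, so that step has no exact size: the limit of > 8000 nM in this assay, at which 1 of the 4 values shown sits.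

Only ethyl and ethoxy have been seen on this ring, which leaves open what an amine, a carboxylic acid or a longer chain would do there. Also open, from the compounds shown here alone, is whether any group on the ring can move the number beyond the scatter of compound 4.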